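Dichlorophenyl in place of pyrimidinyl on a piperazine nitrogen

The source may hold more compounds than are shown below. What is called first, only, known or untested is meant among the compounds shown, and "the series" means these compounds.

Compound 1 `Cc1ncc([N+](=O)[O-])n1CC(O)CN1CCN(c2ccccc2)CC1` — in a toxicity assay on HeLa cells (Homo sapiens) for cytotoxicity, read by MTT assay, with a stated time of 24 h (on this read-out lower numbers stand for stronger inhibition and higher numbers for weaker inhibition), compound 1 gives > 5000000 nM, a limit of the assay.
Compound 2 `Cc1ncc([N+](=O)[O-])n1CC(O)CN1CCN(c2ncccn2)CC1` — in this assay compound 2 gives 3930000 nM.

In this assay compound 2 holds the only number shown; the one further value is a limit (the limit of > 5000000 nM in this assay, at which 1 of the 2 values shown sits). Compound 3 `Cc1ncc([N+](=O)[O-])n1CC(O)CN1CCN(c2cccc(Cl)c2Cl)CC1` differs from compound 2 by 2,3-dichlorophenyl in place of pyrimidin-2-yl on an amine nitrogen in a ring. For the measured compounds named here, the only step that bears on this change is an at least 1.2-fold lower number from compound 1 to compound 2 (0.10 log units; that floor lies within the scatter), which runs the other way and lies within the scatter. Compound 3 is therefore expected to show a step of a 1.3-fold higher number from compound 2 to compound 3 (0.10 log units; within the scatter), no more than the scatter, and possibly only a limit again. The estimate for compound 3 is 5000000 nM, with a range from 2000000 nM to 12000000 nM.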

Compound 3, half-maximal inhibitory concentration: > 5000000 nM
Compound 3: a limit, no number; the forecaster's own chance of this, stated with the estimate: 50%; the middle value sits exactly at the limit.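

In this assay, replacing pyrimidin-2-yl with 2,3-dichlorophenyl on this amine nitrogen gives an at least 1.2-fold higher number from compound 2 to compound 3 (0.10 log units; that floor lies within the scatter), so the data do not separate these two groups. The step from compound 1 to compound 3 cannot be read, as both values are limits. Adding the two chlorines to the phenyl of compound 1 gives no number either, and compound 3 ends at a limit, as compound 1 does: the limit of > 5000000 nM in this assay, at which 2 of the 3 values shown sit.

From the compounds shown here alone, it remains open how far beyond the limit compound 1 and compound 3 lie. Going by these compounds, it is also open whether a benzyl group or a longer chain on this nitrogen would give a number beyond the scatter from that of compound 2.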